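The source may report more compounds than this note shows. Statements on the series, on what has been measured and on what is new or still open speak of the compounds shown alone.

In a functional assay on HUVEC cells (Homo sapiens) for inhibition (a higher number here means a weaker inhibitor, a lower number a stronger inhibitor), compound 3 (`CC(=O)c1ccc(NC(=O)Nc2ccc(N(C)c3ccnc(Nc4cccc(CS(C)(=O)=O)c4)n3)cc2)cc1`) gives 2 nM as the lowest of three numbers, ahead of compound 1 (`CN(c1ccc(NC(=O)Oc2ccccc2)cc1)c1ccnc(Nc2cccc(CS(C)(=O)=O)c2)n1`) at 224 nM and compound 2 (`CN(c1ccc(NC(=N)Nc2ccccc2)cc1)c1ccnc(Nc2cccc(CS(C)(=O)=O)c2)n1`) at 596 nM on the same scale. Compound 4 (`CCCCNC(=O)Nc1ccc(N(C)c2ccnc(Nc3cccc(CS(C)(=O)=O)c3)n2)cc1`) is not yet measured and has butyl in place of 4-acetylphenyl on an amide-type nitrogen. Two measured steps at this same end of the molecule are large (a 110-fold lower number from compound 1 to compound 3 (2.05 log units; beyond the scatter)) and (a 300-fold lower number from compound 2 to compound 3 (2.47 log units; beyond the scatter)). Both keep an aromatic ring at that end, so neither shows what losing the ring does, and they guide the size only loosely. A move towards a higher number, meaning a weaker inhibitor, is still expected in this assay for this change. The estimated step is sizeable (a 15-fold higher number from compound 3 to compound 4 (1.18 log units; beyond the scatter)). Compound 4 is expected to read 30 nM (range 6 nM to 200 nM).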

Compound 4, half-maximal inhibitory concentration: 2 nM
Beside the measured number, compound 4's estimate is 15-fold (1.18 log units) above it; measured number outside the range, below it.
By their numbers in this assay, from the lowest: compounds 3 and 4 (each within the scatter of the next); then compound 1; then compound 2.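

Without the ring, potency in this assay holds: butyl on the amide-type nitrogen matches 4-acetylphenyl (no change at the digits printed from compound 3 to compound 4 (within the scatter)), so an aromatic ring at this end is not required among these compounds. The large gains also persist with this open chain (a 110-fold lower number from compound 1 to compound 4 (2.05 log units; beyond the scatter)) and (a 300-fold lower number from compound 2 to compound 4 (2.47 log units; beyond the scatter)), so they do not depend on the 4-acetylphenyl group. Nothing available explains why two such different groups read alike. Still open, going by these compounds, is how a shorter chain such as methyl, a longer chain, or a butyl chain ending in an amine would read. Plain cyclohexyl, a ring that is not aromatic, is equally open.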